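The source may report more compounds than this note shows. Statements on the series, on what has been measured and on what is new or still open speak of the compounds shown alone.

Measured compounds:
Compound 1, `N#Cc1c(-c2ccc(Cl)cc2)nc(SCC(=O)Nn2c(COc3ccc(Cl)cc3Cl)nc3ccccc3c2=O)[nH]c1=O`: 61.5%
Compound 2, `N#Cc1c(-c2ccc(O)cc2)nc(SCC(=O)Nn2c(COc3ccc(Cl)cc3Cl)nc3ccccc3c2=O)[nH]c1=O`: 61.5%
Compound 3, `N#Cc1c(Cl)nc(SCC(=O)Nn2c(COc3ccc(Cl)cc3Cl)nc3ccccc3c2=O)nc1-c1ccc(Cl)cc1`: 61.5%

All three were tested in a functional assay on the whole organism (strain albino) for inhibition, with Rattus norvegicus as the target, read by paw edema, with stated times of 1 h and 0.5 h, at a dose of 100 mg/kg by the oral route; a lower number here means less inhibition, a higher number more inhibition at the dose given (going by the name of the read-out). Compound 1 and compound 2 share one core and differ only by hydroxy in place of chloro on an aromatic carbon; that change gave no change at the digits printed from compound 1 to compound 2 (within the scatter). Compound 3 carries a different core, and the difference between the two cores is not broken down here. In this assay compound 3 gives 61.5%, level with compound 1 and compound 2 within the scatter.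

Compound 4, `N#Cc1c(Cl)nc(SCC(=O)Nn2c(COc3ccc(Cl)cc3Cl)nc3ccccc3c2=O)nc1-c1ccc(O)cc1`, has not yet been measured. It stands to compound 3 as compound 2 stands to compound 1: the difference is hydroxy in place of chloro on an aromatic carbon, with the same surroundings described at the place of change, so it is the same change seen before. The step is expected to be no change at the digits printed from compound 3 to compound 4 (within the scatter) in this assay, because on the other core the same change gave no change at the digits printed from compound 1 to compound 2 (within the scatter). On that basis compound 4 is expected to give 61.5%, with an estimated range from 48% to 72%.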

Compound 4, a percentage reported as inhibition, in the whole organism at one dose (the size of the read-out at that dose, not a potency): 67.3%
For compound 4 the middle estimate is 5.8 percentage points below the measured one; measured number inside the range.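

In this assay, hydroxy in place of chloro on an aromatic carbon gave a number 5.8 percentage points higher from compound 3 to compound 4 (within the scatter). Set beside the earlier step on the core of compound 1, the result on the second core does not differ from it: the same change on two cores in this assay, no change at the digits printed (within the scatter) from compound 1 to compound 2 and a number 5.8 percentage points higher (within the scatter) from compound 3 to compound 4, 5.8 percentage points apart, within the scatter of two such steps. This shows that, for these two cores, the change from 4-chlorophenyl to 4-hydroxyphenyl carried across without a difference that can be told from the scatter, but since neither step stands clear of the scatter, it does not show that the change has any effect on either core, nor that an effect would transfer to a third core or to another dose.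

The compounds shown leave open how other groups at the same place, such as an amine, a carboxylic acid or a methoxy group, would read in this assay. They also leave open whether the two cores would still match with a group that moved the reading beyond the scatter.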